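The source may hold more compounds than are shown below. What is called first, only, known or untested is meant among the compounds shown, and "the series" means these compounds.

Going by the values given here, compound 2 `C=C1C(=O)OC[C@@H]1CCOC(=O)Nc1ccc(I)cc1` gives 790 nM in a functional assay on RAW264.7 cells (Mus musculus) for inhibition, with a stated time of 30 min (on this read-out higher numbers stand for weaker inhibition and lower numbers for stronger inhibition), the second highest of the three numbers measured so far. Among the compounds with values here, compound 1 `C=C1C(=O)OC[C@H]1CCOC(=O)Nc1ccc(I)cc1` gives 490 nM, and the only measured step, a 1.6-fold higher number from compound 1 to compound 2 (0.21 log units; within the scatter), rests on the fact that compounds 1 and 2 differ only in the configuration as drawn and says nothing about the aromatic substituent. Compound 3 `C=C1C(=O)OC[C@H]1CCOC(=O)Nc1cc(C(F)(F)F)cc(C(F)(F)F)c1` gives 960 nM in this assay. Compound 4 `C=C1C(=O)OC[C@@H]1CCOC(=O)Nc1ccc(C(=O)OCCCC)cc1` is compound 2 with butoxycarbonyl in place of iodo on an aromatic carbon. Within the data shown here, no measured step covers such a change; compounds 1 and 3 differ at that ring and their numbers lie close together, which suggests this position tolerates different groups. The expected step of a 1.0-fold higher number from compound 2 to compound 4 (0.01 log units; within the scatter) is therefore no larger than the usual scatter. Compound 4 is estimated at 800 nM, within 300 nM to 2500 nM.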

Compound 4, half-maximal inhibitory concentration: 860 nM
Compound 4: the middle estimate sits 1.1-fold (0.03 log units) below what was measured, within the range that was stated.
By their numbers in this assay, from the lowest: compounds 1, 2, 4 and 3 (each within the scatter of the next).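

Putting butoxycarbonyl in place of iodo gives a 1.1-fold higher number from compound 2 to compound 4 (0.04 log units; within the scatter) in this assay. This is the first step shown that changes only the group on the aromatic ring, and it shows that a much larger group carrying hydrogen-bond acceptors can replace iodo there without a step beyond the scatter. Nothing available explains why the number holds.

The compounds shown leave open whether an amine, a carboxylic acid or a longer chain at this place would also stay within the scatter of compound 2.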